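Shifting a methyl along the linker of compound 1

The compounds below may be only part of what the source reports. "The series", "measured", "known", "first", "only" and "open" are said of these compounds alone.

For the measured compounds named here, compound 1 `N[C@@H](COP(=O)(O)OCCOC(=O)CCc1ccccc1OCc1cccc(Oc2ccccc2)c1)C(=O)O` is one of two compounds measured in an assay on HEK293 cells for agonist activity at putative P2Y purinoceptor 10 (Mus musculus), with a stated time of 1 h; on this read-out higher numbers stand for larger maximal responses and lower numbers for smaller maximal responses. In this assay compound 1 gives 20.8%, the higher of the two numbers, though only by a margin that repeated measurements could erase. Compound 2 `C[C@H](COP(=O)(O)OC[C@H](N)C(=O)O)OC(=O)CCc1ccccc1OCc1cccc(Oc2ccccc2)c1` differs from compound 1 by a methyl in place of hydrogen on a saturated chain carbon bound to an oxygen next to a carbonyl group and a saturated chain carbon; in this assay compound 2 gives 13.8%, and the step of a number 7 percentage points lower from compound 1 to compound 2 (within the scatter) stays within the scatter.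

Compound 3 `C[C@H](COC(=O)CCc1ccccc1OCc1cccc(Oc2ccccc2)c1)OP(=O)(O)OC[C@H](N)C(=O)O` has not been measured. It differs from compound 1 by methyl in place of hydrogen on a saturated chain carbon bound to an oxygen on an unsaturated carbon and a saturated chain carbon. Going by the values given here, the only comparable step in the data is the one from compound 1 to compound 2, where a methyl enters elsewhere on the same linker and the maximal response barely moves. The expectation for compound 3 is therefore a step of a number 4.8 percentage points lower from compound 1 to compound 3 (within the scatter), no larger than the scatter, in either direction. Compound 3 is estimated to reach 16%, with a range from 6% to 28%.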

Compound 3, largest response reached (Emax), in percent of the reference or control that the assay uses: 13.2%
Compound 3: the middle estimate sits 2.8 percentage points above what was measured; the measured number falls inside the stated range.
By their numbers in this assay, from the lowest: compounds 3, 2 and 1 (each within the scatter of the next).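

Placing a methyl in place of hydrogen on a saturated chain carbon bound to an oxygen on an unsaturated carbon gives a step in this assay of a number 7.6 percentage points lower from compound 1 to compound 3 (within the scatter), so this position also shows no change that can be told apart from repeated-measurement noise. The opening comparison covered only the other methyl position, with a number 7 percentage points lower from compound 1 to compound 2 (within the scatter), so there are now two positions on the linker where a single methyl leaves the maximal response within the scatter of compound 1, and neither can be singled out as the better or worse place for it. No supporting measurement here bears on why the response stays so close.

On these data alone, what remains open is whether this position would respond to a larger or different group, such as an ethyl, a hydroxyl or an amine, in place of the methyl. Also open, as far as these compounds go, is how this assay would respond to a longer chain in the linker, which could show whether its length matters more than a single added methyl.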